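The compounds below may be only part of what the source reports. "The series", "measured", "known", "first", "only" and "open" are said of these compounds alone.

Compound 1 `Cc1cc(C)cc(Sc2c[nH]c3ccc(Cl)cc23)c1`: 1200 nM
Compound 2 `COc1cc(Sc2c[nH]c3ccc(Br)cc23)cc(OC)c1OC`: 43 nM

Both values come from a functional assay on MCF7 cells (Homo sapiens) for inhibition, with a stated time of 48 h; a lower number here means a stronger inhibitor, a higher number a weaker inhibitor. Compound 2 holds the lower of the two numbers, and so is the stronger inhibitor of the pair. Compound 2 gives 43 nM while compound 1 gives 1200 nM, a gap beyond the scatter. These two compounds differ in more than one place, so their gap cannot be pinned on any single change.

The next compound is compound 3 `COc1cc(Sc2c[nH]c3ccc(N)cc23)cc(OC)c1OC`, which keeps everything in compound 2 except one group: amino in place of bromo on an aromatic carbon. The swap puts amino in place of bromo on an aromatic carbon, in the six-membered aromatic ring of carbon only that is part of the fused system. For the measured compounds named here, no measured pair here shows this swap, so the data offer no direct guide to its effect.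

With compound 2 already at 43 nM, a modest loss in this assay seems the likeliest outcome, though a result within the scatter remains possible. The expected change is a 3.0-fold higher number from compound 2 to compound 3 (0.48 log units; beyond the scatter). For compound 3 the estimated value is 130 nM, with an expected range of 30 nM to 700 nM.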

Compound 3, half-maximal inhibitory concentration: 260 nM
Compound 3: the middle estimate sits 2.0-fold (0.30 log units) below what was measured; the range from low to high includes it.
By their numbers in this assay, from the lowest: compound 2; then compound 3; then compound 1.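

In this assay, for the compounds shown here, putting amino in place of bromo on this aromatic carbon gives a 6.0-fold higher number from compound 2 to compound 3 (0.78 log units; beyond the scatter), the first change in this set that sits in a single place and so can be read on its own. The position is therefore sensitive to what it carries: swapping one heavy atom for another, with amino adding a hydrogen-bond donor and a hydrogen-bond acceptor that bromo does not have, is enough to move the number beyond the scatter, although the step is modest and compound 3 still gives 260 nM in this assay. No supporting measurement accompanies these compounds to account for the size of this step.

As far as these compounds go, whether a hydroxyl, a fluoro or an acetamide on the same aromatic carbon would give a number closer to that of compound 2 or that of compound 3 remains open. Also open, from the compounds shown here alone, is whether the same swap from bromo to amino would give a step of similar size on the core of compound 1, since a single pair shows it on one core only.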